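Moving a Methyl Group on Compound 3

The source may hold more compounds than are shown below. What is called first, only, known or untested is meant among the compounds shown, and "the series" means these compounds.

compound 1 `O=C(Nc1ccccc1)[C@@H]1CCCN1C(=O)CSc1nc2ccccc2[nH]1` gives 1400 nM
compound 2 `COc1ccccc1-c1ccccc1NC(=O)[C@@H]1CCCN1C(=O)CCc1nc2ccccc2[nH]1` gives 86 nM
compound 3 `Cn1c(SCC(=O)N2CCC[C@H]2C(=O)Nc2ccccc2-n2cccc2)nc2ccccc21` gives 9 nM

In an assay on CHO cells for displacement of a labelled ligand from Orexin/Hypocretin receptor type 1 (Homo sapiens) (a higher number here means a weaker inhibitor, a lower number a stronger inhibitor), compound 3 gives the lowest of the three numbers; compound 2 stands nearest and compound 1 furthest, both gaps beyond the scatter. Compound 4 `Cc1ccc2[nH]c(SCC(=O)N3CCC[C@H]3C(=O)Nc3ccccc3-n3cccc3)nc2c1` has the same atoms as compound 3, joined differently: 5-methyl-1H-benzimidazol-2-yl in place of 1-methyl-1H-benzimidazol-2-yl on a sulfur. Among the measured compounds shown here, no pair of measured compounds shares this change, so the expectation rests on the values alone. Compound 1 also carries a hydrogen on the ring nitrogen, but it differs from compound 3 elsewhere too, so nothing firm follows. A modest step upward, a 2.8-fold higher number from compound 3 to compound 4 (0.44 log units; beyond the scatter), is expected. Compound 4 is estimated at 25 nM, within 8 nM to 80 nM.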

Compound 4, inhibition constant: 3 nM
The estimate for compound 4 lay 8.3-fold (0.92 log units) above the measured number; the whole stated range lies above it.
By their numbers in this assay, from the lowest: compound 4; then compound 3; then compound 2; then compound 1.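

In this assay, 5-methyl-1H-benzimidazol-2-yl in place of 1-methyl-1H-benzimidazol-2-yl on a sulfur gives a 3.0-fold lower number from compound 3 to compound 4 (0.48 log units; beyond the scatter) and so a stronger inhibitor. The methyl group is therefore not required on the ring nitrogen here, and the change adds a hydrogen-bond donor while removing a hydrogen-bond acceptor. No available measurement accounts for the step. The compounds shown cannot separate the effect of freeing the ring nitrogen from that of placing the methyl group on the other ring. They also leave open how a chlorine at that place, or an ethyl group on the ring nitrogen, would behave.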